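Swapping One Halogenated Ring on the Sulfonamide

This account rests on a few compounds, and the source may have more. Where it says the series, first, only, none or still open, it means among the compounds named here.

In an assay on cells for inhibition of HSP60/HSP10 (Homo sapiens), with a stated time of 60 min (on this read-out lower numbers stand for stronger inhibition and higher numbers for weaker inhibition), compound 1 `O=S(=O)(Nc1ccc(-c2nc3ccccc3o2)cc1)c1cccc(Cl)c1` gives 54000 nM. Among the values shown it stands highest of the two that are numbers. Compound 2 `CS(=O)(=O)Nc1ccc(-c2nc3cc(NS(=O)(=O)c4ccc(Cl)s4)ccc3o2)cc1` gives 43000 nM in this assay, and the gap between the two lies within the usual scatter, so they cannot be told apart. Compound 3 `COc1cccc(S(=O)(=O)Nc2ccc3oc(-c4ccccc4)nc3c2)c1` gives > 100000 nM in this assay, which is a limit of the measurement rather than a number (the limit of > 100000 nM in this assay, at which 1 of the 3 values shown sits). Among the compounds with values here, no two of these three compounds differ in just one place, so no measured step can be drawn from them.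

Compound 4 `O=S(=O)(Nc1ccc(-c2nc3ccccc3o2)cc1)c1ccccc1F` differs from compound 1 in one place: 2-fluorophenyl in place of 3-chlorophenyl on a sulfonyl sulfur. The shared core and the sulfonamide link stay the same. Within the data shown here, no measured step of this kind exists to lean on, and compound 1 is already far from potent at 54000 nM. The expectation is therefore a small step in this assay that stays within the scatter, with no clear direction. The step from compound 1 to compound 4 is expected to be about a 1.1-fold higher number from compound 1 to compound 4 (0.05 log units; within the scatter). Compound 4 is estimated to give 60000 nM, between 25000 nM and 150000 nM, with a real chance that only a limit is reported.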

Compound 4, half-maximal inhibitory concentration: > 100000 nM
Compound 4: a limit, no number; the forecaster's own chance of this, stated with the estimate: 30%; at least 1.6-fold (0.22 log units) between middle value and limit.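

Within the data shown here, this is the first measured step at the ring on the sulfonyl sulfur: with 2-fluorophenyl in place of 3-chlorophenyl, this assay shows an at least 1.8-fold higher number from compound 1 to compound 4 (0.26 log units; that floor lies within the scatter) and no exact size for the change. Only a floor is known for this step, and that floor lies within the scatter, so the change cannot be called a real loss, even though the true gap could be larger. The result for compound 4 is a limit of the measurement and not a number, which makes it the second compound shown to read this way: the limit of > 100000 nM in this assay, at which 2 of the 4 values shown sit.

The identity of the halogen and its place on the ring change together in this one step, so the compounds shown cannot separate the two. Also open, as far as these compounds go, is how this assay would read with an amine or a carboxylic acid on this ring in place of the halogen, and whether any such group would bring the value clearly away from the limit.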